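Moving the fluorine on the amide nitrogen's aryl group

This account rests on a few compounds, and the source may have more. Where it says the series, first, only, none or still open, it means among the compounds named here.

Measured compounds:
Compound 1 `Cc1ccccc1N(C)C(=O)c1ccc(-c2ccc(O)cc2F)o1`: 10 nM
Compound 2 `Cc1cccc(F)c1N(C)C(=O)c1ccc(-c2ccc(O)cc2)o1`: 120 nM

In an assay on T47D cells for inhibition of 17-beta-hydroxysteroid dehydrogenase type 1 (Homo sapiens), read by HPLC, with a stated time of 24 h (a higher number here means a weaker inhibitor, a lower number a stronger inhibitor), compound 2 stands at the higher of the two numbers, and the gap to compound 1 lies beyond the usual scatter. Compound 3 `Cc1cc(F)ccc1N(C)C(=O)c1ccc(-c2ccc(O)cc2)o1` is not yet measured. It differs from compound 2 in one place: 4-fluoro-2-methylphenyl in place of 2-fluoro-6-methylphenyl on an amide-type nitrogen. Among the compounds with values here, with no measured pair showing this change, the direction is open; a modest move to a lower number is expected, though a step within the scatter would not surprise. Compound 3 is estimated at 40 nM, between 10 nM and 150 nM, an expected step of a 3.0-fold lower number from compound 2 to compound 3 (0.48 log units; beyond the scatter).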

Compound 3, half-maximal inhibitory concentration: 7.6 nM
For compound 3 the middle estimate is 5.3-fold (0.72 log units) above the measured one; the whole stated range lies above it.
By their numbers in this assay, from the lowest: compounds 3 and 1 (each within the scatter of the next); then compound 2.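

In this assay, rearranging the same atoms on the aryl group at this amide-type nitrogen produces a 16-fold lower number from compound 2 to compound 3 (1.20 log units; beyond the scatter), so activity here depends strongly on how the fluorine and methyl are placed, not merely on their presence. Among these two groups, 4-fluoro-2-methylphenyl gives the lower number. Nothing shown here accounts for the size of this step.

Going by these compounds, whether chlorine or methoxy could replace the fluorine of 4-fluoro-2-methylphenyl without losing activity remains open. It is also unknown whether the same change would give a similar step on the core of compound 1.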